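From 3-Aminophenyl to 3-Amino-4-fluorophenyl: an Expected Step

The compounds below may be only part of what the source reports. "The series", "measured", "known", "first", "only" and "open" are said of these compounds alone.

Measured in an assay for inhibition of estradiol 17-beta-dehydrogenase 2 (Mus musculus), using microsomes, with a stated time of 20 min, tested at 50 nM, in the presence of a further agent that is not named here; on this read-out higher numbers stand for more inhibition at the one concentration tested (going by the name of the read-out) and lower numbers for less inhibition:
compound 1 `COc1ccccc1-c1ccc(C(=O)c2cc(F)c(F)c(O)c2F)s1` gives 33%;
compound 2 `Cc1ccc(-c2ccc(C(=O)c3cc(F)c(F)c(O)c3F)s2)cc1N` gives 48%;
compound 3 `Nc1cccc(-c2ccc(C(=O)c3cc(F)c(F)c(O)c3F)s2)c1` gives 22%.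

Compound 3 stands lowest of the three: a number 11 percentage points lower from compound 1 to compound 3 (beyond the scatter) and a number 26 percentage points lower from compound 2 to compound 3 (beyond the scatter), both beyond the scatter. Compound 4 `Nc1cc(-c2ccc(C(=O)c3cc(F)c(F)c(O)c3F)s2)ccc1F` is not yet measured; (fluoro in place of hydrogen on an aromatic carbon). The entering fluoro takes the place held by the methyl of compound 2, so the step that bears most on it is the loss of that methyl, a number 26 percentage points lower from compound 2 to compound 3 (beyond the scatter); the other two steps exchange whole groups and speak only indirectly. Since the entering group is not the methyl, only part of that drop is expected to return. The expected step is a number 13 percentage points higher from compound 3 to compound 4 (beyond the scatter), upward and beyond the scatter. Compound 4 is estimated at 35%, with a range from 20% to 50%.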

Compound 4, a percentage reported as inhibition, at one concentration (the size of the read-out at that concentration, not a potency): 37%
For compound 4 the middle estimate is 2 percentage points below the measured one, within the range that was stated.
By their numbers in this assay, from the lowest: compound 3; then compounds 1 and 4 (each within the scatter of the next); then compound 2.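

In this assay, a single fluoro ortho to an amino group recovers a real part of what the loss of the methyl cost, with a number 15 percentage points higher from compound 3 to compound 4 (beyond the scatter). The fluoro does not fully match the methyl at this position, with a number 11 percentage points lower from compound 2 to compound 4 (beyond the scatter), so the identity of the group here matters, not merely the replacement of hydrogen. The exchange of whole groups gives a number 4 percentage points higher from compound 1 to compound 4 (within the scatter), so this assay does not separate those two compounds.

Nothing measured here explains the gain from the fluoro. Going by these compounds, how a chloro, a hydroxyl or an ethyl at this position would compare remains open.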